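This account rests on a few compounds, and the source may have more. Where it says the series, first, only, none or still open, it means among the compounds named here.

Measured compounds:
compound 1, `COc1ccc(F)cc1CNCCCNc1ccnc2cc(Cc3ccc(C#N)cc3)ccc12`: 6050 nM
compound 2, `COc1ccc(-c2ccc3c(NCCCNCc4cccc(OC)c4O)ccnc3c2)cc1`: 1600 nM
compound 3, `FC(F)(F)c1ccc(-c2ccc3c(NCCCNCc4ccco4)ccnc3c2)cc1`: 3470 nM

All three were read in an ADME assay on HepG2 cells (Homo sapiens) for cytotoxicity, read by luminescence, CellTiter-Glo and ATP content, with a stated time of 72 h; a higher number here means that more compound is needed for the effect, a lower number that less compound is needed. Compound 2 gives the lowest number of the three; compound 3 comes nearest, beyond the scatter, and compound 1 stands furthest away. Compound 4 (`COc1cccc(CNCCCNc2ccnc3cc(-c4ccc(F)cc4)ccc23)c1O`) differs from compound 2 by fluoro in place of methoxy on an aromatic carbon. Within the data shown here, no pair of measured compounds is separated by this single change, so its size is uncertain. Compound 3, at 3470 nM, carries yet another group in that outer position and still sits close to compound 2, so a modest move is expected. The step from compound 2 to compound 4 is expected to be small, a 1.4-fold higher number from compound 2 to compound 4 (0.14 log units; within the scatter), with a slight rise if anything. Compound 4 is therefore estimated at 2200 nM, within 900 nM to 5500 nM.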

Compound 4, half-maximal effective concentration: 6840 nM
The estimate for compound 4 lay 3.1-fold (0.49 log units) below the measured number, outside the stated range (above it).
By their numbers in this assay, from the lowest: compound 2; then compounds 3, 1 and 4 (each within the scatter of the next).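

In this assay, among these compounds, the change from 4-methoxyphenyl to 4-fluorophenyl gives a 4.3-fold higher number from compound 2 to compound 4 (0.63 log units; beyond the scatter) and so offers the first reading of a single change. It shows that this position, para to a large group, is not indifferent to what it carries: replacing methoxy with fluoro alone moves the number beyond the scatter. No measurement available here explains this step. The compounds shown leave open how an amine or a carboxylic acid at this position would compare with methoxy and fluoro. They also leave open whether the same change gives a similar step when the rest of the molecule differs.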